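The compounds below may be only part of what the source reports. "The series", "measured", "known", "first", "only" and "open" are said of these compounds alone.

Measured in a functional assay on K562 cells (Homo sapiens) for cytotoxicity, read by MTT assay, with a stated time of 72 h; a lower number here means a stronger inhibitor, a higher number a weaker inhibitor:
compound 1, `[O-][n+]1nc(NCOCc2ccc(C(F)(F)F)cc2)[n+]([O-])c2ccccc21`, gives 1240 nM
compound 2, `COc1ccc(COCNc2n[n+]([O-])c3ccccc3[n+]2[O-])cc1`, gives 660 nM
compound 3, `O=[N+]([O-])c1cccc(COCNc2n[n+]([O-])c3ccccc3[n+]2[O-])c1`, gives 650 nM

Of the three numbers in this assay, compound 2 holds the second highest; its value and that of compound 3 lie close together, and the gap to compound 1 is the widest of the set, yet even that gap is within the scatter: a 1.9-fold lower number from compound 1 to compound 2 (0.27 log units; within the scatter).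

The step to the unmeasured compound 4, `CCCCCOCNc1n[n+]([O-])c2ccccc2[n+]1[O-]`, is of a different kind. butyl in place of 4-methoxyphenyl on a saturated chain carbon bound to an oxygen on a saturated carbon The whole ring that carried the methoxy group is gone, and a plain chain takes its place on the saturated chain carbon bound to an oxygen on a saturated carbon.

Among the measured compounds shown here, only one measured step speaks here, and only indirectly: the exchange of one group for another on the ring between compound 1 and compound 2 stayed within the scatter. For the measured compounds named here, no measured compound lacks the ring, so nothing in the data tells how removing it shifts the value in this assay. With three values lying within a narrow band, the expectation for compound 4 is a number near compound 2, with no step beyond the scatter and a wide range to cover the untested change: the expected step is a 1.4-fold higher number from compound 2 to compound 4 (0.13 log units; within the scatter), giving an estimated 900 nM for compound 4, between 350 nM and 2500 nM.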

Compound 4, half-maximal inhibitory concentration: 3300 nM
Beside the measured number, compound 4's estimate is 3.7-fold (0.56 log units) below it, outside the stated range (above it).
By their numbers in this assay, from the lowest: compounds 3, 2 and 1 (each within the scatter of the next); then compound 4.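

Exchanging the 4-methoxyphenyl for butyl on a saturated chain carbon bound to an oxygen on a saturated carbon is the only change shown that moves the number in this assay beyond the scatter (a 5.0-fold higher number from compound 2 to compound 4 (0.70 log units; beyond the scatter)). Among the compounds shown here, the one earlier step at this position swapped one group for another on the ring and stayed within the scatter (a 1.9-fold lower number from compound 1 to compound 2 (0.27 log units; within the scatter)), so across these two steps, removing the ring itself matters more than changing what it carries, and this position is not indifferent to the group placed there. Nothing among the data shown accounts for the shift.

Butyl is the only group without a ring here, and because it replaces the ring and its methoxy group together, the compounds shown cannot separate the contribution of the ring from that of the methoxy group. They also leave open whether an unsubstituted phenyl, a longer chain or a chain ending in an amine would give a number nearer that of compound 2 or one further from it.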